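Swapping the ring on the pyridine core of a vanilloid-channel antagonist

The source may hold more compounds than are shown below. What is called first, only, known or untested is meant among the compounds shown, and "the series" means these compounds.

Compound 1: `CC(C(=O)NCc1ccc(C(F)(F)F)nc1N1CC=CCC1)c1ccc(NS(C)(=O)=O)c(F)c1` — 0.3 nM
Compound 2: `CC(C(=O)NCc1ccc(C(F)(F)F)nc1N1CCC2(CC1)CC(c1ccccc1)=NO2)c1ccc(NS(C)(=O)=O)c(F)c1` — 6.1 nM

Two compounds share an amide-linked core carrying a trifluoromethyl group, a fluorinated methanesulfonamide aryl and a saturated ring on the pyridine. Within the data shown here, in a functional assay on CHO-K1 cells for antagonist activity at transient receptor potential cation channel subfamily V member 1 (Homo sapiens), read by FLIPR (a lower number here means a stronger inhibitor, a higher number a weaker inhibitor), compound 1 gives 0.3 nM, the lowest of the two numbers known. Compound 2, which carries a spiro-fused ring system in the same place, gives 6.1 nM in this assay; that is a higher number, and the gap between the two lies beyond the scatter of repeated measurements. Both values therefore show that this position is sensitive to what is attached.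

Compound 3, `CC(C(=O)NCc1ccc(C(F)(F)F)nc1N1CCN(C)CC1)c1ccc(NS(C)(=O)=O)c(F)c1`, is not yet measured. It differs from compound 1 in one place: a group of 7 heavy atoms (5 carbon, 2 nitrogen; one six-membered non-aromatic ring with 2 hetero atoms) in place of a group of 6 heavy atoms (5 carbon, 1 nitrogen; one six-membered non-aromatic ring with 1 hetero atom), on an aromatic carbon. Among the measured compounds shown here, no step between two measured compounds matches this change, so its size can only be expected, not read off. For the measured compounds named here, the ring is of similar size to the one it replaces, so a modest rise is expected, smaller than the one seen for compound 2. The step of a 6.7-fold higher number from compound 1 to compound 3 (0.82 log units; beyond the scatter) is expected to be a moderate loss. Compound 3 is estimated at 2 nM, with a range from 0.3 nM to 15 nM.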

Compound 3, inhibition constant: 146 nM
For compound 3 the middle estimate is 73-fold (1.86 log units) below the measured one, and the stated range ends below it.
By their numbers in this assay, from the lowest: compound 1; then compound 2; then compound 3.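

In this assay, replacing the ring of compound 1 with 4-methylpiperazin-1-yl, on the aromatic carbon next to the ring nitrogen, brings a 490-fold higher number from compound 1 to compound 3 (2.69 log units; beyond the scatter), which shows that this position responds strongly even when a six-membered non-aromatic ring stays in place and the group grows by only one heavy atom. Size alone therefore does not order these groups: compound 2, with its much bigger spiro-fused ring system, gives 6.1 nM, while the close-sized replacement in compound 3 gives 146 nM, so what this position registers here is the identity of the ring rather than its bulk. Nothing available here accounts for this loss.

The change from compound 1 to compound 3 alters several things at once, adding a second ring nitrogen and a methyl group and removing the double bond, and the compounds shown do not separate these contributions. Going by these compounds, it remains open how a plain piperidine, a piperazine without the methyl group or a morpholine would read at this position, and which of these changes carries the step.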